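Ring size change at the amide of compound 3

The source may hold more compounds than are shown below. What is called first, only, known or untested is meant among the compounds shown, and "the series" means these compounds.

Going by the values given here, compound 3 `O=C(CCSc1nc2cc(Cl)ccc2o1)N1CCCCC1` sits second highest of the three numbers so far in an ADME assay on microsomes from liver (Mus musculus) for metabolic stability, read by LC-MS, using NADPH, with a stated time of 45 min, tested at 0.5 uM; on this read-out higher numbers stand for fast clearance and lower numbers for slow clearance: in this assay compound 3 gives 128 mL/min/g. Its nearest neighbour is compound 2 `COc1ccc2oc(SCCC(=O)N3CCCC3)nc2c1`, which in this assay gives 198 mL/min/g; the gap between the two lies within the scatter. Among the compounds with values here, the furthest is compound 1 `CS(=O)(=O)C1CCN(C(=O)CCSc2nc3cc(Cl)ccc3o2)CC1`, which in this assay gives 2.6 mL/min/g; the only step between measured compounds is a 49-fold higher number from compound 1 to compound 3 (1.69 log units; beyond the scatter).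

Compound 4 `CC1CCN(C(=O)CCSc2nc3cc(Cl)ccc3o2)C1` differs from compound 3 in one place: 3-methylpyrrolidin-1-yl in place of piperidin-1-yl on a carbonyl carbon.

Within the data shown here, the one measured step concerns the replacement of methylsulfonyl by hydrogen on a saturated ring carbon, not a change of the amide ring itself, so no step bears directly on the change from compound 3 to compound 4. Among the measured compounds shown here, with no direct precedent, the expectation for compound 4 is a step of a 1.0-fold higher number from compound 3 to compound 4 (0.01 log units; within the scatter), which is estimated to fall within the scatter, and in this assay compound 4 is expected to give 130 mL/min/g, with a range from 60 mL/min/g to 260 mL/min/g.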

Compound 4, intrinsic clearance in a liver preparation (reported as CLH), per the amount of preparation that the assay uses: 90.7 mL/min/g
The estimate for compound 4 lay 1.4-fold (0.16 log units) above the measured number; low and high end bracket the measured number.
By their numbers in this assay, from the lowest: compound 1; then compounds 4, 3 and 2 (each within the scatter of the next, the first and the last beyond it).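

Exchanging piperidin-1-yl for 3-methylpyrrolidin-1-yl on the carbonyl carbon gives a 1.4-fold lower number from compound 3 to compound 4 (0.15 log units; within the scatter) in this assay, so a five-membered non-aromatic ring bearing a methyl and a six-membered one with the same atoms cannot be told apart on this read-out. Among the compounds that differ in one place, the earlier comparison showed only the effect of removing methylsulfonyl, a 49-fold higher number from compound 1 to compound 3 (1.69 log units; beyond the scatter), and the new pair adds that this one reshaping of the unsubstituted amide ring does not produce a step of that kind. Compound 3 and compound 4 therefore both remain far from the low number of compound 1, which gives 2.6 mL/min/g, and nothing available here accounts for the close agreement of the two amides.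

From the compounds shown here alone, it remains open whether methylsulfonyl on the five-membered ring, in place of the methyl of compound 4, would give a step as large as the one seen on the six-membered ring. Going by these compounds, it is equally open whether a morpholin-4-yl group or a carboxylic acid on the amide ring would move the number in this assay beyond the scatter.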